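The source may report more compounds than this note shows. Statements on the series, on what has been measured and on what is new or still open speak of the compounds shown alone.

Two members of a shared core have been tested in a functional assay on the whole organism for inhibition, with Mus musculus as the target, with stated times of 30 min and 2 h, at a dose of 10 mg/kg by the intraperitoneal route; a lower number here means less inhibition, a higher number more inhibition at the dose given (going by the name of the read-out). Compound 1 `COc1cccc(C(=O)NCc2ccc(CNS(=O)(=O)c3ccc(C)cc3)cc2)c1` gives 28% in this assay. Compound 2 `O=C(NCc1ccc(CNS(=O)(=O)c2ccccc2)cc1)c1cccnc1` gives 53% in this assay, the higher of the two numbers, standing above compound 1 by a gap that lies beyond the usual scatter. The two compounds differ in more than one place, so their values are compared only as they stand.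

Compound 3 `Cc1ccccc1C(=O)NCc1ccc(CNS(=O)(=O)c2ccccc2)cc1` has not yet been measured in this assay. It differs from compound 2 in one place: 2-methylphenyl in place of pyridin-3-yl on a carbonyl carbon. For the measured compounds named here, the outcome rests on compound 2 alone, since no single-change step is known among the measured pair. Compound 3 is expected to fall below compound 2, with an estimated step of a number 17 percentage points lower from compound 2 to compound 3 (beyond the scatter) in this assay, which may reach beyond the scatter. The estimate for compound 3 in this assay is 36%, within a range of 16% to 56%.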

Compound 3, a percentage reported as inhibition, in the whole organism at one dose (the size of the read-out at that dose, not a potency): "not active" (no number reported)
Nothing numeric was reported for compound 3; there is nothing to compare the estimate with.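

In this assay, for the compounds shown here, compound 3 gives "not active" (no number reported), so no step from compound 2 can be read. The compounds shown leave open how far the 2-methylphenyl group of compound 3 stands from the pyridin-3-yl group of compound 2 in numbers. Nothing available bears on this result.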